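The source may report more compounds than this note shows. Statements on the series, on what has been measured and on what is new or still open speak of the compounds shown alone.

Of the compounds shown here, two built on one shared core have so far been tested in a functional assay on A549 cells (Homo sapiens) for antiproliferative activity, read by CCK-8 assay, with a stated time of 72 h; a higher number here means a weaker inhibitor, a lower number a stronger inhibitor. Compound 1 `Cc1ccc(C(=O)Nc2cccc(-c3oc4cc(-c5ccc(F)cc5)ccc4c(=O)c3O)c2)cc1` gives 6910 nM. Compound 2 `O=C(Nc1cccc(-c2oc3cc(-c4ccc(F)cc4)ccc3c(=O)c2O)c1)c1ccc(Br)cc1F` gives 46100 nM, the higher of the two numbers and so the weaker inhibitor of the pair. Among the measured compounds shown here, the one step measured so far, a 6.7-fold higher number from compound 1 to compound 2 (0.82 log units; beyond the scatter), is exactly what separates these two.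

Compound 3 `CCCc1ccc(C(=O)Nc2cccc(-c3oc4cc(-c5ccc(F)cc5)ccc4c(=O)c3O)c2)cc1` has not yet been measured. It differs from compound 2 in a single place: 4-propylphenyl in place of 4-bromo-2-fluorophenyl on a carbonyl carbon. This largely reverses the earlier step, since a 4-propylphenyl is much closer to the 4-methylphenyl of compound 1 than to the group it replaces. Because a 6.7-fold higher number from compound 1 to compound 2 (0.82 log units; beyond the scatter) was a modest rise beyond the scatter, a drop of similar size is expected when going back the other way. The estimate for compound 3 is 8000 nM, with a range from 3000 nM to 25000 nM. For compound 3 this amounts to an expected step of a 5.8-fold lower number from compound 2 to compound 3 (0.76 log units; beyond the scatter).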

Compound 3, half-maximal inhibitory concentration: 47600 nM
Beside the measured number, compound 3's estimate is 6.0-fold (0.77 log units) below it; the whole stated range lies below it.
By their numbers in this assay, from the lowest: compound 1; then compounds 2 and 3 (each within the scatter of the next).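

The step of a 6.9-fold higher number from compound 1 to compound 3 (0.84 log units; beyond the scatter) shows that, on this carbonyl carbon, extending the 4-methylphenyl to a 4-propylphenyl is by itself enough to take the number well beyond the scatter, so a small change in chain length matters at this position. With a 1.0-fold higher number from compound 2 to compound 3 (0.01 log units; within the scatter), the 4-propylphenyl and the 4-bromo-2-fluorophenyl cannot be told apart here, even though these two groups carry entirely different substituents, and compound 1 keeps the lowest number of the three. No measured evidence is available on what lies behind these results.

Still open, from the compounds shown here alone, is whether the number climbs gradually with chain length, which a 4-ethylphenyl would test, and how an unsubstituted phenyl would compare. Also open, going by these compounds, is how an amine or a carboxylic acid at the end of that chain would read.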